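Estimating a nitrile-bearing compound from three close relatives

A few compounds are considered here, and "the series" means these few. Any claim that something is new, unique, unknown or untested is made for them only; others in the source may bear on it.

In a functional assay on DU-145 cells (Homo sapiens) for cytotoxicity, read by sulforhodamine B assay, with a stated time of 48 h (a lower number here means a stronger inhibitor, a higher number a weaker inhibitor), compound 1 `C[C@H]1CC[C@@H]2[C@@H](OC(=O)[C@]23CC(c2ccc(Cl)cc2)=NO3)[C@]2(C)C(=O)C=C[C@@]12O` gives 43000 nM and compound 2 `C[C@H]1CC[C@@H]2[C@@H](OC(=O)[C@]23CC(c2ccccc2)=NO3)[C@]2(C)C(=O)C=C[C@@]12O` gives 39800 nM while compound 3 `COc1cc(C2=NO[C@]3(C2)C(=O)O[C@@H]2[C@H]3CC[C@H](C)[C@]3(O)C=CC(=O)[C@@]23C)ccc1O` gives 71000 nM so compound 3 sits level with the other two, within the usual scatter. Compound 4 `C[C@H]1CC[C@@H]2[C@@H](OC(=O)[C@]23CC(c2ccc(C#N)cc2)=NO3)[C@]2(C)C(=O)C=C[C@@]12O` keeps the shared core but carries 4-cyanophenyl in place of 4-hydroxy-3-methoxyphenyl on a carbon with a double bond to nitrogen and has not yet been measured. Among the compounds with values here, three measured steps bear on this change. They are a 1.7-fold higher number from compound 1 to compound 3 (0.22 log units; within the scatter) and a 1.8-fold higher number from compound 2 to compound 3 (0.25 log units; within the scatter) and also a 1.1-fold lower number from compound 1 to compound 2 (0.03 log units; within the scatter) and each of them stays within the scatter. Within the data shown here, the three groups measured at this place therefore leave the number about where it was, and nothing measured so far points to a large effect from the new group. The expected step is a 1.5-fold lower number from compound 3 to compound 4 (0.17 log units; within the scatter) and this estimate lies within the scatter, so no real change is expected. Compound 4 is estimated at 48000 nM with a likely range of 24000 nM to 90000 nM for repeat measurements.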

Compound 4, half-maximal inhibitory concentration: 26000 nM
Beside the measured number, compound 4's estimate is 1.8-fold (0.27 log units) above it; the measured number falls inside the stated range.
By their numbers in this assay, from the lowest: compounds 4, 2, 1 and 3 (each within the scatter of the next, the first and the last beyond it).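

In this assay, within the data shown here, a 2.7-fold lower number from compound 3 to compound 4 (0.44 log units; beyond the scatter) is the first step at this position to clear the scatter, so the group on this carbon can shift the number, though only modestly. That step stands alone: a 1.5-fold lower number from compound 2 to compound 4 (0.18 log units; within the scatter) and a 1.7-fold lower number from compound 1 to compound 4 (0.22 log units; within the scatter) both stay within the scatter, so the 4-cyanophenyl compound remains level with the phenyl and 4-chlorophenyl compounds and differs clearly only from the 4-hydroxy-3-methoxyphenyl compound. Nothing measured here accounts for that difference.

Going by these compounds, it remains open whether the hydroxy or the methoxy of compound 3 matters more for the gap to compound 4, as the two appear only together. Also open, on these data alone, is how an amine or a carboxylic acid in place of the cyano group would read in this assay.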